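This account rests on a few compounds, and the source may have more. Where it says the series, first, only, none or still open, it means among the compounds named here.

Measured in a functional assay on trachea (Cavia porcellus); a lower number here means a stronger inhibitor, a higher number a weaker inhibitor:
compound 1, `CCN1CC[C@@]2(OC)OC(N)=C(C#N)[C@@H](c3ccccc3)[C@@H]2C1`: 23400 nM
compound 2, `CCN1CC[C@@]2(OC)OC(N)=C(C#N)[C@@H](c3ccc(Br)cc3)[C@@H]2C1`: 13200 nM
compound 3, `CO[C@@]12CCN(C)C[C@H]1[C@H](c1ccc(Cl)cc1)C(C#N)=C(N)O2`: 10500 nM

Compound 3 gives the lowest of the three numbers in this assay; its gap to compound 2 lies within the scatter, and only its gap to compound 1 lies beyond it. Compound 4, `CCN1CC[C@@]2(OC)OC(N)=C(C#N)[C@@H](c3ccc(Cl)cc3)[C@@H]2C1`, is not yet measured; it differs from compound 3 by methyl in place of hydrogen on a saturated chain carbon bound to an amine nitrogen in a ring, which cut one bond further out reads methyl to ethyl. Among the compounds with values here, the only measured step, a 1.8-fold lower number from compound 1 to compound 2 (0.25 log units; within the scatter), concerns the aromatic ring and says nothing direct about the amine substituent. Compound 2 and compound 3, which differ in both places at once, sit within the scatter of each other. A step within the scatter is therefore expected, a 1.0-fold higher number from compound 3 to compound 4 (0.02 log units; within the scatter), and compound 4 is estimated at 11000 nM with a range from 5000 nM to 25000 nM.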

Compound 4, half-maximal inhibitory concentration: 14900 nM
Compound 4: the middle estimate sits 1.4-fold (0.13 log units) below what was measured, and the stated range covers the measured number.
By their numbers in this assay, from the lowest: compounds 3, 2, 4 and 1 (each within the scatter of the next, the first and the last beyond it).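

With the aromatic chloro held fixed, methyl in place of hydrogen on a saturated chain carbon bound to an amine nitrogen in a ring, which also reads methyl to ethyl, now has its own step in this assay (a 1.4-fold higher number from compound 3 to compound 4 (0.15 log units; within the scatter)). With ethyl held fixed, chloro in place of bromo (a 1.1-fold higher number from compound 2 to compound 4 (0.05 log units; within the scatter)) and chloro in place of hydrogen (a 1.6-fold lower number from compound 1 to compound 4 (0.20 log units; within the scatter)) also give steps within the scatter, so no single change shown here moves the number beyond it. Nothing available explains these steps. From the compounds shown here alone, whether a propyl or benzyl group in place of ethyl would give a step beyond the scatter remains open.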